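Hydroxymethyl for Hydrogen on a Benzyl Ester Amide Series

The compounds below may be only part of what the source reports. "The series", "measured", "known", "first", "only" and "open" are said of these compounds alone.

Measured compounds:
compound 1 `NC(=O)CC[C@H](NC(=O)c1cc2ccccc2cn1)C(=O)OCc1ccccc1` with 44.5 nM
compound 2 `O=C(CNC(=O)c1cc2ccccc2cn1)OCc1ccccc1` with 57.4 nM
compound 3 `O=C(C[C@@H]1CCCN1C(=O)c1cc2ccccc2cn1)OCc1ccccc1` with 53.4 nM

In a functional assay on HL-60 cells (Homo sapiens) for antiproliferative activity, read by MTT assay, with a stated time of 48 h (a higher number here means a weaker inhibitor, a lower number a stronger inhibitor), compound 1 gives 44.5 nM, compound 2 gives 57.4 nM and compound 3 gives 53.4 nM. Compound 2 stands at the highest of the three numbers, with compound 3 nearest and compound 1 furthest, but both gaps lie within the scatter, so the three compounds cannot be told apart on these numbers.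

The unmeasured compound 4 `O=C(N[C@@H](CO)C(=O)OCc1ccccc1)c1cc2ccccc2cn1` differs from compound 2 in one place: hydroxymethyl in place of hydrogen on a saturated chain carbon bound to an amide-type nitrogen and a carbonyl carbon. Going by the values given here, the one measured step that touches the same place is a 1.3-fold higher number from compound 1 to compound 2 (0.11 log units; within the scatter), which stayed within the scatter even though a much larger chain was removed. Among the compounds with values here, no measured step brings in a hydroxymethyl, so nothing in the data points to a direction for this change.

Compound 4 is therefore expected to show a step of a 1.1-fold lower number from compound 2 to compound 4 (0.04 log units; within the scatter) in this assay, that is, no movement beyond the scatter. Compound 4 is estimated at 52 nM, with a range from 25 nM to 110 nM.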

Compound 4, half-maximal inhibitory concentration: 70.4 nM
Compound 4: middle estimate off by 1.4-fold (0.13 log units), on the low side, within the range that was stated.
By their numbers in this assay, from the lowest: compounds 1, 3, 2 and 4 (each within the scatter of the next).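

In this assay, going by these compounds alone, the hydroxymethyl in place of hydrogen on the saturated chain carbon gives a 1.2-fold higher number from compound 2 to compound 4 (0.09 log units; within the scatter) and so stays within the scatter, which shows that a group the earlier compounds did not carry at this place leaves the number unresolved from that of the hydrogen compound. The exchange of the longer chain of compound 1 for the hydroxymethyl gives a 1.6-fold higher number from compound 1 to compound 4 (0.20 log units; within the scatter) and also stays within the scatter. Hydrogen, 2-carbamoylethyl and hydroxymethyl at this carbon therefore cannot be told apart in this assay, so the earlier insensitivity to removing a large chain now extends to a small group with a hydroxy end, though only across these three compounds. No supporting evidence bears on these numbers.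

The compounds shown leave open whether an amine or a carboxylic acid at this carbon would move the number beyond the scatter. They also leave open whether a plain methyl or a longer chain ending in hydroxy would do so, since every group seen here at this place lies within the scatter of the others.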